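The compounds below may be only part of what the source reports. "The series", "measured", "known", "first", "only" and "open" are said of these compounds alone.

Measured in a functional assay on HL-60 cells (Homo sapiens) for cytotoxicity, read by CCK-8 assay, with a stated time of 24 h; on this read-out higher numbers stand for weaker inhibition and lower numbers for stronger inhibition
Compound 1 `C=CC(=O)N1C(=O)CC(c2ccc(C(F)(F)F)cc2)Sc2ccccc21` gives 106000 nM
Compound 2 `C=CC(=O)N1C(=O)CC(c2ccc(Cl)cc2)Sc2ccccc21` gives 95700 nM
Compound 3 `C=CC(=O)N1C(=O)CC(c2cccs2)Sc2ccccc21` is not yet measured

On these two numbers, compound 2 stands within the scatter of compound 1. Compound 3 carries thiophen-2-yl in place of 4-chlorophenyl on a saturated ring carbon. Among the measured compounds shown here, only one measured step bears on this, chloro in place of trifluoromethyl on an aromatic carbon (a 1.1-fold lower number from compound 1 to compound 2 (0.04 log units; within the scatter)), and it stayed within the scatter. That step left the aromatic ring itself unchanged, so it guides only loosely, and no step beyond the scatter is expected in this assay here. The expected step is small (a 1.0-fold higher number from compound 2 to compound 3 (0.02 log units; within the scatter)). For compound 3 the estimate is 100000 nM with 50000 nM to 200000 nM as the expected range.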

Compound 3, half-maximal inhibitory concentration: 695000 nM
Estimate against measurement, compound 3: 7.0-fold (0.84 log units) below, outside the stated range (above it).
By their numbers in this assay, from the lowest: compounds 2 and 1 (each within the scatter of the next); then compound 3.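

In this assay, the change on the saturated ring carbon next to the ring sulfur gives a 7.3-fold higher number from compound 2 to compound 3 (0.86 log units; beyond the scatter), a step beyond the scatter. This position therefore responds to the aromatic ring it carries, whereas the swap on the phenyl ring, a 1.1-fold lower number from compound 1 to compound 2 (0.04 log units; within the scatter), stayed within the scatter. Nothing available accounts for this step.

From the compounds shown here alone, whether the five-membered ring or its sulfur matters more remains open. So does whether plain phenyl or pyridin-3-yl on this carbon would stand nearer compound 2 or compound 3.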